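Compound 4: nitro in place of methoxy

This account rests on a few compounds, and the source may have more. Where it says the series, first, only, none or still open, it means among the compounds named here.

Values measured in a functional assay on A549 cells (Homo sapiens) for inhibition, read by MTT assay, with a stated time of 72 h; on this read-out lower numbers stand for stronger inhibition and higher numbers for weaker inhibition:
Compound 1 `COc1ccc(-c2nnc(SCCCN3CCN(c4nc5ccccc5o4)CC3)o2)cc1`: 93500 nM
Compound 2 `O=[N+]([O-])c1ccc(-c2nnc(SCCCN3CCN(c4nc5ccccc5o4)CC3)o2)cc1`: 90800 nM
Compound 3 `COc1ccc(-c2nnc(SCCCN3CCN(c4nc5ccccc5s4)CC3)o2)cc1`: 90300 nM

Compound 3, at 90300 nM, lies within the scatter of both other compounds, so the three cannot be ranked in this assay. Compound 4 `O=[N+]([O-])c1ccc(-c2nnc(SCCCN3CCN(c4nc5ccccc5s4)CC3)o2)cc1`, not yet measured, differs from compound 3 in one place: nitro in place of methoxy on an aromatic carbon. In words, this is nitro in place of methoxy on an aromatic carbon, with 4-methoxyphenyl becoming 4-nitrophenyl.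

The same exchange appears in one measured pair, which carries 1,3-benzoxazol-2-yl instead of 1,3-benzothiazol-2-yl. That pair shows a 1.0-fold lower number from compound 1 to compound 2 (0.01 log units; within the scatter). The other measured step is the exchange between those two groups themselves, and it shows a 1.0-fold lower number from compound 1 to compound 3 (0.02 log units; within the scatter). Neither step leaves the scatter, although a single pair for each change is thin evidence, and the two changes have not been seen together in a measured compound.

On these two steps, no shift beyond the scatter is expected in this assay. The estimated step is a 1.0-fold lower number from compound 3 to compound 4 (0.00 log units; within the scatter). For compound 4 the expected value is 90000 nM, within an estimated range of 55000 nM to 145000 nM.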

Compound 4, half-maximal inhibitory concentration: 96600 nM
Estimate against measurement, compound 4: 1.1-fold (0.03 log units) below; the range from low to high includes it.
By their numbers in this assay, from the lowest: compounds 3, 2, 1 and 4 (each within the scatter of the next).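

In this assay, the exchange of 4-methoxyphenyl for 4-nitrophenyl can now be read on a second core, where it gives a 1.1-fold higher number from compound 3 to compound 4 (0.03 log units; within the scatter), and the two readings of this change agree: the same change on two cores in this assay, a 1.0-fold lower number (0.01 log units; within the scatter) from compound 1 to compound 2 and a 1.1-fold higher number (0.03 log units; within the scatter) from compound 3 to compound 4, 1.1-fold (0.04 log units) apart, within the scatter of two such steps. The exchange of 1,3-benzoxazol-2-yl for 1,3-benzothiazol-2-yl, read with 4-nitrophenyl in place of 4-methoxyphenyl, gives a 1.1-fold higher number from compound 2 to compound 4 (0.03 log units; within the scatter), and it too agrees across the two cores: the same change on two cores in this assay, a 1.0-fold lower number (0.02 log units; within the scatter) from compound 1 to compound 3 and a 1.1-fold higher number (0.03 log units; within the scatter) from compound 2 to compound 4, 1.1-fold (0.04 log units) apart, within the scatter of two such steps. The two changes have now been seen together in one compound, and across these four compounds neither one leaves the scatter, whichever group stands at the other place.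

The compounds shown leave open whether an amine or a carboxylic acid on this aromatic carbon, or a longer chain in the shared core, would move the number beyond the scatter in this assay. They also leave open whether the same lack of separation among these four compounds would hold on cells other than A549.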